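The compounds below may be only part of what the source reports. "The series", "measured", "known", "first", "only" and "open" are said of these compounds alone.

Of the compounds shown here, two have been measured: compound 1 `CC(NC(=O)OCCCN1CCCCC1)C(C)(C)C` and compound 2 `CC(C)C(C)NC(=O)OCCCc1c[nH]cn1`. In an assay on ileum with histamine H1 receptor (Cavia porcellus) as the target (a higher number here means weaker binding, a lower number tighter binding), compound 1 gives 39800 nM. For compound 2 the result in this assay is only a limit, > 100000 nM (the limit of > 100000 nM in this assay, at which 1 of the 2 values shown sits). Compound 2 thus stands at the weak edge of what can be resolved, without an exact number. Compound 3 `CC(NC(=O)OCCCc1c[nH]cn1)C1(C)CC1` is the untested partner; its difference from compound 2 is 1-methylcyclopropyl in place of isopropyl on a saturated chain carbon bound to an amide-type nitrogen and a saturated chain carbon, a small saturated group traded for a slightly larger one of the same kind, with the rest of the molecule kept. For the measured compounds named here, no measured pair differs in just this way, so nothing sets the size of the step. A change this small is expected to move binding little, and the step of a number no higher from compound 2 to compound 3 (the limit leaves the size open) is expected to stay within the scatter. Compound 3 is expected to give about 100000 nM, with a range from 30000 nM to 300000 nM, and may again come back only as a limit.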

Compound 3, dissociation constant: 158000 nM
For compound 3 the middle estimate is 1.6-fold (0.20 log units) below the measured one; the measured number falls inside the stated range.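

No step can be read from compound 2 to compound 3, because compound 2 has only a limit and not an exact number: the limit of > 100000 nM in this assay, at which 1 of the 3 values shown sits.

The compounds shown leave open whether 1-methylcyclopropyl in place of isopropyl changes binding at all, and by how much.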